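Swapping Fluoro for Methoxy on a Shared Core

The source may report more compounds than this note shows. Statements on the series, on what has been measured and on what is new or still open speak of the compounds shown alone.

Compound 1 `COc1ccc(-c2ccnc(Nc3ccc(Cl)cc3Cl)n2)cc1`: 839 nM
Compound 2 `COc1cccc(Nc2nccc(-c3ccc(F)cc3)n2)c1`: > 1000 nM

In an assay on isolated protein for inhibition of phosphatidylinositol 4,5-bisphosphate 3-kinase catalytic subunit beta isoform (Homo sapiens) (on this read-out lower numbers stand for stronger inhibition and higher numbers for weaker inhibition), compound 1 gives 839 nM. For compound 2 only a limit is known: in this assay compound 2 gives > 1000 nM, which is a limit of the assay and not a number, as shown by the limit of > 1000 nM in this assay, at which 1 of the 2 values shown sits. Compound 3 `COc1ccc(-c2ccnc(Nc3cccc(OC)c3)n2)cc1` differs from compound 2 by methoxy in place of fluoro on an aromatic carbon. Within the data shown here, no measured step between two compounds describes this change, so the expected step from compound 2 to compound 3, a step that the limit leaves unreadable from compound 2 to compound 3, is none beyond the scatter. Compound 3 is therefore estimated at 1500 nM, expected between 500 nM and 5000 nM.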

Compound 3, half-maximal inhibitory concentration: 729 nM
For compound 3 the middle estimate is 2.1-fold (0.31 log units) above the measured one, and the stated range covers the measured number.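

In this assay, methoxy in place of fluoro on this aromatic carbon, para to a large group, gives an at least 1.3-fold lower number from compound 2 to compound 3 (0.13 log units; that floor lies within the scatter). With methoxy here, compound 3 gives a measured number, so the position can carry this larger group without the reading reaching the limit of the assay. The true size of the step cannot be read because compound 2 stands at a limit, not a number: the limit of > 1000 nM in this assay, at which 1 of the 3 values shown sits.

From the compounds shown here alone, whether the real step exceeds the scatter stays open. So does how an amine or a carboxylic acid on this carbon would read.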